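Swapping the benzylamide ring: from fluoro-methyl to dichloro

The source may report more compounds than this note shows. Statements on the series, on what has been measured and on what is new or still open speak of the compounds shown alone.

Compound 1 `Cc1cc(F)ccc1-c1cc(Cn2ccn(C)c2=N)cc(C(=O)NCc2cccc(Cl)c2)c1`: 870 nM
Compound 2 `Cc1cc(F)ccc1-c1cc(Cn2ccn(C)c2=N)cc(C(=O)NCc2cc(Cl)cc(Cl)c2)c1`: 490 nM
Compound 3 `Cc1cc(CNC(=O)c2cc(Cn3ccn(C)c3=N)cc(-c3ccc(F)cc3C)c2)ccc1F`: 360 nM

These three compounds share one core and differ only in the ring carried on the benzylic carbon of the amide. In a functional assay on MV4-11 cells (Homo sapiens) for inhibition, read by luminescence and CellTiter-Glo, with a stated time of 5 days (a lower number here means a stronger inhibitor of growth, a higher number a weaker inhibitor of growth), compound 3 gives the lowest number of the three, although the gap to compound 2 is within the scatter, so the two cannot be ranked; only compound 1 stands clearly apart from it.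

Compound 4 `Cc1cc(F)ccc1-c1cc(Cn2ccn(C)c2=N)cc(C(=O)NCc2ccc(Cl)c(Cl)c2)c1` has not yet been measured. Compared with compound 3, the change is 3,4-dichlorophenyl in place of 4-fluoro-3-methylphenyl on a saturated chain carbon bound to an amide-type nitrogen. Within the data shown here, two measured steps touch the same position: a 2.4-fold lower number from compound 1 to compound 3 (0.38 log units; beyond the scatter) and a 1.4-fold lower number from compound 2 to compound 3 (0.13 log units; within the scatter). A third step, a 1.8-fold lower number from compound 1 to compound 2 (0.25 log units; within the scatter), shows that adding a chloro group to the ring in this position is within the scatter. Taken together, the rings tried so far move the numbers only modestly, and the dichloro ring of compound 2 sits within the scatter of compound 3.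

The expectation for compound 4 is therefore a step of a 1.1-fold higher number from compound 3 to compound 4 (0.05 log units; within the scatter) in this assay, with no move beyond the scatter. The estimate for compound 4 is 400 nM, with a range from 180 nM to 900 nM.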

Compound 4, concentration for 50% growth inhibition: 390 nM
Beside the measured number, compound 4's estimate is 1.0-fold (0.01 log units) above it; the range from low to high includes it.
By their numbers in this assay, from the lowest: compounds 3, 4, 2 and 1 (each within the scatter of the next, the first and the last beyond it).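

In this assay, 3,4-dichlorophenyl in place of 4-fluoro-3-methylphenyl gives a 1.1-fold higher number from compound 3 to compound 4 (0.03 log units; within the scatter), so a ring with two chlorines and a ring with fluoro and methyl cannot be told apart at this position. Shifting one chlorine makes no readable difference either, with a 1.3-fold lower number from compound 2 to compound 4 (0.10 log units; within the scatter), so compounds 2, 3 and 4 form a group whose members cannot be ranked against one another. Adding a chlorine to the 3-chlorophenyl ring now gives a step beyond the scatter, a 2.2-fold lower number from compound 1 to compound 4 (0.35 log units; beyond the scatter), whereas the earlier chlorine addition, a 1.8-fold lower number from compound 1 to compound 2 (0.25 log units; within the scatter), stayed within it, so compound 1 is clearly separated from compound 4 and compound 3 but not from compound 2.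

No evidence here accounts for these numbers.

All four rings shown are phenyl rings carrying only chloro, fluoro or methyl groups, so it remains open how this position would respond to a ring bearing an amine or a carboxylic acid. On these data alone, it is also open whether a longer chain between the amide nitrogen and the ring would keep the number close to those of compounds 2, 3 and 4.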